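The compounds below may be only part of what the source reports. "The series", "measured", "known", "first", "only" and "open" are said of these compounds alone.

- Compound 1 `O=C(OC1CCC(CN2CCN(c3cc(=O)c4cc(C(F)(F)F)cc([N+](=O)[O-])c4s3)CC2)CC1)c1ccccc1`: 68.1%
- Compound 2 `O=c1cc(N2CCN(CC3CCC(O)CC3)CC2)sc2c([N+](=O)[O-])cc(C(F)(F)F)cc12`: 51.2%

In an ADME assay on cells (Hepatocyte, Mus musculus) for metabolic stability, with a stated time of 30 min (a higher number here means that more of the compound is left, a lower number that less of the compound is left), compound 2 gives 51.2%, the lower of the two numbers, and it lies beyond the scatter below compound 1. Among the compounds with values here, the next step leads to compound 3 `O=C(OC1CCC(CN2CCN(c3cc(=O)c4cc(C(F)(F)F)cc([N+](=O)[O-])c4s3)CC2)CC1)c1cccs1`, which has no measurement yet. The structural change is (thiophen-2-yl)carbonyl in place of hydrogen on an oxygen on a saturated carbon. In words, (thiophen-2-yl)carbonyl sits in place of hydrogen on an oxygen on a saturated carbon. Within the data shown here, only one measured step bears on this: a number 16.9 percentage points lower from compound 1 to compound 2 (beyond the scatter). There, hydrogen took the place of benzoyl at the same oxygen, so compound 3 runs in the opposite direction, though with a different group entering. Among the measured compounds shown here, no measurement yet covers (thiophen-2-yl)carbonyl itself, so this single pair is a rough guide. The expected change is therefore a rise of similar size, a number 14.8 percentage points higher from compound 2 to compound 3 (beyond the scatter). For compound 3 the estimated value is 66%, with an expected range from 51% to 81%.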

Compound 3, percent of the compound remaining: 1.8%
The estimate for compound 3 lay 64.2 percentage points above the measured number, and the stated range ends above it.
By their numbers in this assay, from the lowest: compound 3; then compound 2; then compound 1.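

In this assay, the earlier pair suggested that an ester on this oxygen leaves more of the compound than the free hydroxy, but with (thiophen-2-yl)carbonyl on the same oxygen the result is a number 49.4 percentage points lower from compound 2 to compound 3 (beyond the scatter) instead. Exchanging only the ring on the carbonyl carbon, thiophen-2-yl in place of phenyl, gives a number 66.3 percentage points lower from compound 1 to compound 3 (beyond the scatter), so among these compounds the outcome depends on what is attached to the carbonyl, not just on an ester being present. Nothing available explains why these two rings differ so sharply.

From the compounds shown here alone, it remains open whether a pyridine ring or a plain methyl on the carbonyl carbon would behave more like phenyl or like thiophen-2-yl. The percentage remaining also does not show which part of compound 3 is changed during the incubation.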